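Series notes: side-chain change from compound 2 to compound 3

This account rests on a few compounds, and the source may have more. Where it says the series, first, only, none or still open, it means among the compounds named here.

In an ADME assay on microsomes from liver (Rattus norvegicus) for metabolic stability (a lower number here means that the compound disappears faster, a higher number that the compound lasts longer), compound 1 `CCn1ncc2c(F)cc(-c3ccc(C(CC)(CC)c4nnc[nH]4)c(=O)[nH]3)cc21` gives > 3 h, which is a limit of the assay and not a number (the limit of > 3 h in this assay, at which 1 of the 2 values shown sits). Compound 2 `CC(C)C(c1nnc[nH]1)c1ccc(-c2ccc3cccc(F)c3c2)[nH]c1=O` gives 0.552 h in this assay. Going by the values given here, this is the only number measured in the set, so compound 2 cannot be placed against any measured neighbour. Compound 3 `CC(C)C(CC(N)=O)c1ccc(-c2ccc3cccc(F)c3c2)[nH]c1=O` is not yet measured. It differs from compound 2 in one place: carbamoylmethyl in place of 4H-1,2,4-triazol-3-yl on a saturated chain carbon bound to an aromatic carbon and a saturated chain carbon. Among the compounds with values here, no pair of measured compounds differing in a single place is available, so nothing here shows how a change of this kind moves the half-life. The step of a 1.1-fold higher number from compound 2 to compound 3 (0.04 log units; within the scatter) in this assay is therefore expected to be small, in no set direction, and not beyond the scatter of repeated runs. Compound 3 is expected to give about 0.6 h in this assay, with a range from 0.25 h to 1.5 h.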

Compound 3, half-life: < 0.0667 h
Compound 3 ended at the assay's limit; the forecaster's own chance of this, stated with the estimate: 10%; middle value at least 8.9-fold (0.95 log units) from the limit.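

Going by these compounds alone, this is the first single-place step, and it shows that the group on this saturated chain carbon is not a neutral site for the half-life: carbamoylmethyl in place of 4H-1,2,4-triazol-3-yl gives an at least 8.2-fold lower number from compound 2 to compound 3 (0.91 log units; beyond the scatter) in this assay. With the rest of the structure unchanged, the open carbamoylmethyl chain therefore cannot stand in for the five-membered aromatic ring here without a loss beyond the scatter. The true size of the step remains unknown, and the reading gives only its minimum: the limit of < 0.0667 h in this assay, at which 1 of the 3 values shown sits.

Compound 1 differs from compound 2 in more than one place, so it cannot show whether the same change would carry over to another core. As far as these compounds go, how a carboxylic acid, an amine or a longer chain on the same carbon would read in this assay stays open.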